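Compound 3 to compound 4: a new aryl group

The compounds below may be only part of what the source reports. "The series", "measured", "known", "first", "only" and "open" are said of these compounds alone.

In a functional assay on MCF7 cells (Homo sapiens) for antiproliferative activity, read by MTT assay, with a stated time of 72 h (on this read-out higher numbers stand for weaker inhibition and lower numbers for stronger inhibition), compound 3 `O=C(N/N=C/c1ccc(F)cc1)Nc1ccc(Oc2ccnc3[nH]ccc23)cc1` gives 3720 nM, the highest of the two numbers available. Compound 1 `O=C(N/N=C/c1ccc(F)cc1)Nc1ccc(Oc2ccnc3[nH]ccc23)c(F)c1` gives 800 nM, and compound 2 `O=C(N/N=C/c1cccc(Cl)c1Cl)Nc1ccc(Oc2ccnc3[nH]ccc23)c(F)c1` gives "not active" (no number reported). Compound 4 `O=C(N/N=C/c1ccc(O)cc1Br)Nc1ccc(Oc2ccnc3[nH]ccc23)cc1` carries 2-bromo-4-hydroxyphenyl in place of 4-fluorophenyl on a carbon with a double bond to nitrogen. Among the compounds with values here, the one measured step, a 4.7-fold higher number from compound 1 to compound 3 (0.67 log units; beyond the scatter), is a different change, hydrogen in place of fluoro, so it offers only a modest size for a single change. The result for compound 2, "not active" (no number reported), leaves room for a loss when this aryl group is changed. The expected step is a 2.2-fold higher number from compound 3 to compound 4 (0.33 log units; beyond the scatter), a small move towards weaker inhibition. Compound 4 is estimated at 8000 nM, with an expected range of 2000 nM to 30000 nM.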

Compound 4, half-maximal inhibitory concentration: "not active" (no number reported)
For compound 4 the study gives words and no number; there is nothing to compare the estimate with.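

Within the data shown here, compound 4 is reported in words only in this assay, so no step from compound 3 to compound 4 can be read. The compounds shown leave open whether the bromine or the hydroxyl of 2-bromo-4-hydroxyphenyl goes with this result. No measured evidence bears on it.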